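The compounds below may be only part of what the source reports. "The series", "measured", "known", "first", "only" and "open" are said of these compounds alone.

Of the compounds shown here, two have been measured in an assay (Rattus norvegicus) for binding affinity to prostacyclin receptor (Homo sapiens), read by radioligand binding; a lower number here means a stronger inhibitor, a higher number a weaker inhibitor. Compound 1 `Clc1ccc(Sc2ccc(CNC3=NCCN3)cc2)cc1` gives 501 nM. Compound 2 `COc1ccc(Sc2ccc(CC3=NCCN3)cc2)cc1` gives 5010 nM, the higher of the two numbers, and its gap to compound 1 lies beyond the usual scatter of repeated measurements. Compound 3 `COc1ccc(Sc2ccc(CN3CCCC3)cc2)cc1` has not yet been measured in this assay. It differs from compound 2 in one place: a group of 5 heavy atoms (4 carbon, 1 nitrogen; one five-membered non-aromatic ring with 1 hetero atom) in place of a group of 5 heavy atoms (3 carbon, 2 nitrogen; one five-membered non-aromatic ring with 2 hetero atoms), on a saturated chain carbon bound to an aromatic carbon. Going by the values given here, no measured pair in this small set shows this exchange, so nothing here tells directly how large the step will be or which way it goes; the change is substantial, and the expectation is for a further weakening that reaches beyond the scatter, with a 3.0-fold higher number from compound 2 to compound 3 (0.48 log units; beyond the scatter) as the expected step. Compound 3 is therefore estimated at 15000 nM, in a range from 3000 nM to 60000 nM, and there is a fair chance that only a limit rather than a number will be reported.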

Compound 3, inhibition constant: 10000 nM
Beside the measured number, compound 3's estimate is 1.5-fold (0.18 log units) above it; measured number inside the range.
By their numbers in this assay, from the lowest: compound 1; then compounds 2 and 3 (each within the scatter of the next).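

At this position, on a saturated chain carbon bound to an aromatic carbon, this assay gives a 2.0-fold higher number from compound 2 to compound 3 (0.30 log units; within the scatter), so pyrrolidin-1-yl and the ring it replaces cannot be told apart here. The two groups do differ on paper: the one that leaves has 2 nitrogens, 1 double bond outside aromatic rings, 1 hydrogen-bond donor and 2 hydrogen-bond acceptors, while pyrrolidin-1-yl has 1 nitrogen, 0 hydrogen-bond donors and 1 hydrogen-bond acceptor, and in this pair those differences leave no readable mark on the number. Nothing measured here gives a reason for this result.

From the compounds shown here alone, whether a group without a ring, such as a dimethylamino group, or one without a basic nitrogen, such as a carboxylic acid, would match these numbers stays open. Also open, going by these compounds, is whether the same exchange would give a similar step on the core of compound 1.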